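The compounds below may be only part of what the source reports. "The series", "measured", "known", "first", "only" and "open" are said of these compounds alone.

Measured so far: compound 1 `CN1CCN(CCCN(C(=O)Nc2ccc(F)c(Cl)c2)C2CCc3ccccc3C2)CC1`, 380 nM in an assay on CHO cells for binding affinity to melanin-concentrating hormone receptor 1 (Homo sapiens); on this read-out lower numbers stand for stronger inhibition and higher numbers for weaker inhibition; compound 2 `CN1CCN(CCCN(C(=O)Nc2ccc(F)c(Cl)c2)C2CCc3ccc(N)cc3C2)CC1`, 260 nM.

Compound 2 has the lower of the two numbers, yet the gap to compound 1 lies within the scatter, so no real order between them is claimed. Compound 3 `CC(=O)Nc1ccc2c(c1)CC(N(CCCN1CCN(C)CC1)C(=O)Nc1ccc(F)c(Cl)c1)CC2` carries acetyl in place of hydrogen on a nitrogen on an aromatic ring. Going by the values given here, the only measured step, a 1.5-fold lower number from compound 1 to compound 2 (0.16 log units; within the scatter), introduced the very amino group that compound 3 now bears acetylated, and it stayed within the scatter, so it gives no lean in either direction. Compound 3 is therefore expected to give 200 nM in this assay, a step of a 1.3-fold lower number from compound 2 to compound 3 (0.11 log units; within the scatter) expected to remain inside the scatter, within a range from 60 nM to 650 nM.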

Compound 3, inhibition constant: 6 nM
Compound 3: the middle estimate sits 33-fold (1.52 log units) above what was measured, and the stated range ends above it.
By their numbers in this assay, from the lowest: compound 3; then compounds 2 and 1 (each within the scatter of the next).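

Acetyl in place of hydrogen on the nitrogen on the aromatic ring gives a 43-fold lower number from compound 2 to compound 3 (1.64 log units; beyond the scatter) in this assay, whereas the amino group alone had produced no step beyond the scatter. Against the core of compound 1, adding the acetamido group gives a 63-fold lower number from compound 1 to compound 3 (1.80 log units; beyond the scatter), so this position can respond strongly, though only with the acetyl present among the compounds shown. No measurement here explains this result.

The compounds shown leave open whether a longer acyl chain such as propanoyl, or a methanesulfonyl group, on that nitrogen would hold this level. They also leave open whether acetamido would do the same elsewhere on the aromatic ring.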